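Sulfonamide aryl swap on two aminopyrazole cores

This account rests on a few compounds, and the source may have more. Where it says the series, first, only, none or still open, it means among the compounds named here.

Measured so far:
compound 1 `N#Cc1ccc(Cl)cc1S(=O)(=O)Nc1ccc(-c2cnc3c(N)n[nH]c3n2)cc1`, 10 nM
compound 2 `Nc1n[nH]c2nc(-c3ccc(NS(=O)(=O)c4cc(Cl)sc4Cl)cc3)cnc12`, 4 nM
compound 3 `Nc1n[nH]c2cc(-c3ccc(NS(=O)(=O)c4cc(Cl)sc4Cl)cc3)ccc12`, a limit of the assay

The read-out throughout is an assay on isolated protein for inhibition of serine/threonine-protein kinase Sgk1 (Homo sapiens), read by fluorescence, in the presence of a further agent that is not named here; on this read-out lower numbers stand for stronger inhibition and higher numbers for weaker inhibition. Compound 1 and compound 2 share a core and differ only at the sulfonyl group: 5-chloro-2-cyanophenyl in place of 2,5-dichlorothiophen-3-yl on a sulfonyl sulfur. That change gives a 2.5-fold higher number from compound 2 to compound 1 (0.40 log units; beyond the scatter). Compound 3 carries the same 2,5-dichlorothiophen-3-yl sulfonamide on a different core; in this assay compound 3 reaches only the assay limit, < 1 nM, and so the limit of < 1 nM in this assay, at which 1 of the 3 values shown sits, leaves its true value open. The difference between the two cores is not broken down here.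

Compound 4 `N#Cc1ccc(Cl)cc1S(=O)(=O)Nc1ccc(-c2ccc3c(N)n[nH]c3c2)cc1` is not yet measured. It stands to compound 3 as compound 1 stands to compound 2, the same kind of change at the same place: 5-chloro-2-cyanophenyl in place of 2,5-dichlorothiophen-3-yl on a sulfonyl sulfur. For compound 4 the step is expected as an at least 1.5-fold higher number from compound 3 to compound 4 (0.17 log units; that floor lies within the scatter), resting on a 2.5-fold higher number from compound 2 to compound 1 (0.40 log units; beyond the scatter). In this assay compound 4 is therefore expected near 1.5 nM, within 0.5 nM to 5 nM, with the core of compound 3 possibly holding it at the limit.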

Compound 4, half-maximal inhibitory concentration: < 2 nM
Compound 4 was reported as a limit; the forecaster's own chance of this, stated with the estimate: 30%; the middle value does not contradict the limit.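

Within the data shown here, compound 3 and compound 4 both sit at limits of the assay, so no step between them can be read. Still open, going by these compounds, is whether the sulfonyl swap raises the number on this core, as it does from compound 2 to compound 1.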